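Swapping a methylpiperazine for a sulfamoyl on the aniline

A few compounds are considered here, and "the series" means these few. Any claim that something is new, unique, unknown or untested is made for them only; others in the source may bear on it.

Measured so far:
- compound 1 `CN1CCN(c2ccc(Nc3ncc(/N=C/c4cccs4)c(NC4CCCC4)n3)cc2)CC1`: 21700 nM
- compound 2 `CN1CCN(c2ccc(Nc3ncc(/N=C/c4ccc(C(F)(F)F)cc4)c(NC4CCCC4)n3)cc2)CC1`: 80700 nM

In a functional assay on HT-29 cells (Homo sapiens) for antiproliferative activity, read by MTT assay (a higher number here means a weaker inhibitor, a lower number a stronger inhibitor), compound 1 gives 21700 nM, the lowest of the two numbers shown. For the measured compounds named here, the only other compound, compound 2, gives 80700 nM, and the step of a 3.7-fold higher number from compound 1 to compound 2 (0.57 log units; beyond the scatter) changes the group on the carbon carrying the double bond to nitrogen.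

Compound 3 `NS(=O)(=O)c1ccc(Nc2ncc(/N=C/c3cccs3)c(NC3CCCC3)n2)cc1` differs from compound 1 at a different place: sulfamoyl in place of 4-methylpiperazin-1-yl on an aromatic carbon. Going by the values given here, the one measured step concerns the group on the other side of the molecule and says nothing about the anilino substituent, so there is no measured guide for this change. For that reason the expectation for compound 3 rests on compound 1 alone, and the step of a 1.1-fold lower number from compound 1 to compound 3 (0.04 log units; within the scatter) is expected to be small, with a wide range to reflect the lack of any comparable step.

The estimate for compound 3 in this assay is 20000 nM, expected to fall between 5000 nM and 80000 nM.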

Compound 3, half-maximal inhibitory concentration: 9950 nM
Compound 3: middle estimate off by 2.0-fold (0.30 log units), on the high side, and the stated range covers the measured number.
By their numbers in this assay, from the lowest: compound 3; then compound 1; then compound 2.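

In this assay, for the compounds shown here, the step of a 2.2-fold lower number from compound 1 to compound 3 (0.34 log units; beyond the scatter) is the first measured change on the aniline side of the molecule, and it shows that this position affects the read-out, although the effect is modest. The 4-methylpiperazin-1-yl is therefore not needed to keep this level of activity: sulfamoyl, a smaller group with no ring and a hydrogen-bond donor that the group it replaces lacks, gives a lower number on the same scaffold, with the thiophen-2-yl group held constant. Nothing available explains why the number moves in this direction.

With a single change at this position, the compounds shown cannot separate the loss of the ring from the arrival of sulfamoyl itself, and a morpholine, a simple amine or a carboxylic acid on the same aromatic carbon would help to tell these apart. Going by these compounds alone, it also remains open whether sulfamoyl would lower the number in the same way when the 4-(trifluoromethyl)phenyl group replaces thiophen-2-yl, since the step at that other site has so far been seen only with 4-methylpiperazin-1-yl in place.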